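Growth inhibition notes: exchanging the substituted phenyl group

The compounds below may be only part of what the source reports. "The series", "measured", "known", "first", "only" and "open" are said of these compounds alone.

In a functional assay on MIA PaCa-2 cells (Homo sapiens) for inhibition, read by MTT assay, with a stated time of 48 h, tested at 10 uM (on this read-out lower numbers stand for less inhibition of growth and higher numbers for more inhibition of growth at the one concentration tested), compound 1 (`Cc1cc(=O)c2c(O)cc(OCc3ccccc3)c([C@H]3CCN(C)C[C@H]3O)c2o1`) gives 14% and compound 2 (`Cc1cc(=O)c2c(O)c(CN3CC(O)CC3C(=O)O)c(O)c([C@H]3CCN(C)C[C@H]3O)c2o1`) gives 23%. Compound 3 (`Cc1oc2c([C@H]3CCN(C)C[C@H]3O)c(O)cc(O)c2c(=O)c1C(O)c1ccc([N+](=O)[O-])cc1`) gives 2%, the lowest of the three numbers and beyond the scatter from both others. Compound 4 (`Cc1oc2c([C@H]3CCN(C)C[C@H]3O)c(O)cc(O)c2c(=O)c1C(O)c1c(F)cccc1Cl`) remains unmeasured. It carries 2-chloro-6-fluorophenyl in place of 4-nitrophenyl on a saturated chain carbon bound to an aromatic carbon and an oxygen on a saturated carbon. Among the measured compounds shown here, no measured pair isolates this change, so the expectation rests only on the low values seen so far. A small rise, not beyond the scatter, is expected, with an estimated a number 7 percentage points higher from compound 3 to compound 4 (within the scatter). The estimate for compound 4 is 9%, with an expected range of 0% to 22%.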

Compound 4, percent growth inhibition at one concentration: 41%
Estimate against measurement, compound 4: 32 percentage points below; the whole stated range lies below it.
By their numbers in this assay, from the lowest: compound 3; then compounds 1 and 2 (each within the scatter of the next); then compound 4.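

Among the compounds shown here, exchanging 4-nitrophenyl for 2-chloro-6-fluorophenyl in this assay gives a number 39 percentage points higher from compound 3 to compound 4 (beyond the scatter), the first change confined to one place. The group on this saturated chain carbon therefore bears strongly on growth inhibition at the one concentration tested, while the rest of the structure stays the same. Nothing at hand explains the size of this step.

Whether the chlorine or the fluorine accounts for the step stays open. So does what an unsubstituted phenyl or an amine would give on this carbon.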